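The compounds below may be only part of what the source reports. "The series", "measured", "known", "first", "only" and "open" are said of these compounds alone.

Working notes on the nitrofuran amide series.

In an ADME assay on Vero cells (Chlorocebus sabaeus) for cytotoxicity, read by MTT assay, with a stated time of 72 h (on this read-out higher numbers stand for weaker inhibition and lower numbers for stronger inhibition), compound 1 `COc1cccc(-c2csc(NC(=O)c3ccco3)n2)c1` reaches only the limit of the assay, > 90000 nM, which is not a number. Compound 2 `COc1ccc(-c2csc(NC(=O)c3ccc([N+](=O)[O-])o3)n2)cc1` gives 63000 nM in this assay. Compound 3 `O=C(Nc1nc(-c2cccc(C(F)(F)F)c2)cs1)c1ccc([N+](=O)[O-])o1` gives 23900 nM, the lowest of the two numbers shown; the gap to compound 2 is beyond the usual scatter, so compound 3 sits measurably below compound 2 in this assay.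

Compound 4 `O=C(Nc1nc(-c2cccc(NC(=O)C3CCCCC3)c2)cs1)c1ccc([N+](=O)[O-])o1` has not yet been measured. It differs from compound 3 in one place: (cyclohexylcarbonyl)amino in place of trifluoromethyl on an aromatic carbon.

Among the measured compounds shown here, no measured pair shows a step of this kind, so nothing here sets its size. The expectation is a small shift toward a higher number, close to the edge of the scatter, rather than a large move in either direction. Compound 4 is expected to give about 40000 nM in this assay. Compound 4 is estimated to fall between 12000 nM and 120000 nM. In size, the expected step is a 1.7-fold higher number from compound 3 to compound 4 (0.22 log units; within the scatter).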

Compound 4, half-maximal inhibitory concentration: 21900 nM
Beside the measured number, compound 4's estimate is 1.8-fold (0.26 log units) above it; measured number inside the range.
By their numbers in this assay, from the lowest: compounds 4 and 3 (each within the scatter of the next); then compound 2. At a limit, above all of these: compound 1.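

In this assay, the place on the aromatic ring that holds trifluoromethyl in compound 3 takes the larger (cyclohexylcarbonyl)amino with a 1.1-fold lower number from compound 3 to compound 4 (0.04 log units; within the scatter), so the two readings cannot be told apart. Among the compounds shown here, this is the first step that can be read at a single place, and it shows that a group with a non-aromatic ring, a hydrogen-bond donor and a hydrogen-bond acceptor can stand there without separating compound 4 from compound 3. Nothing at hand bears on why these two readings agree.

As far as these compounds go, whether an amine or a carboxylic acid at this place would stay level with compound 3 and compound 4 remains open. So does the reading of a longer chain in place of the cyclohexyl ring.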